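This account rests on a few compounds, and the source may have more. Where it says the series, first, only, none or still open, it means among the compounds named here.

Compound 1 `O=C(Nc1cccc(CNc2nccnc2Cl)c1)NC1CCCC1` is one of three compounds examined in a functional assay on HepG2 cells (Homo sapiens) for antiproliferative activity, read by MTT assay, with a stated time of 48 h; on this read-out lower numbers stand for stronger inhibition and higher numbers for weaker inhibition. There compound 1 gives 18400 nM, the higher of the two numbers returned, while compound 2 `CS(=O)(=O)c1ccc(NC(=O)Nc2cccc(CNc3nccnc3Cl)c2)cc1` gives 15100 nM, a gap that lies within the usual scatter of the assay. For compound 3 `O=C(Nc1cccc(CNc2nccnc2Cl)c1)Nc1cccc2ccccc12` only a limit is recorded, > 40000 nM. The account now follows the step from compound 1 to compound 4 `O=C(Nc1cccc(CNc2nccnc2Cl)c1)Nc1ccc(Cl)cc1Br`, which has not yet been measured in this assay: 2-bromo-4-chlorophenyl in place of cyclopentyl on an amide-type nitrogen. Of the other two compounds, compound 2 sits within the scatter of compound 1 and compound 3 returned only a limit, so a step of no more than the scatter, or a modest rise, is expected in this assay a 1.1-fold higher number from compound 1 to compound 4 (0.06 log units; within the scatter). Compound 4 is estimated at 21000 nM, between 9000 nM and 45000 nM.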

Compound 4, half-maximal inhibitory concentration: 6720 nM
Compound 4: middle estimate off by 3.1-fold (0.49 log units), on the high side, and the stated range ends above it.
By their numbers in this assay, from the lowest: compound 4; then compounds 2 and 1 (each within the scatter of the next). At a limit, above all of these: compound 3.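

In this assay, 2-bromo-4-chlorophenyl in place of cyclopentyl on an amide-type nitrogen gives a 2.7-fold lower number from compound 1 to compound 4 (0.44 log units; beyond the scatter), showing that a change at this position can move the read-out beyond the scatter, which the values of compound 1 and compound 2 had not shown. Compound 3 also carries an aromatic group at this position, yet it returned only a limit of the assay: the limit of > 40000 nM in this assay, at which 1 of the 4 values shown sits.

Which part of the new group accounts for the step remains open: the bromine, the chlorine or the aromatic ring itself. A plain phenyl, or a phenyl with only one of these halogens, would separate them, and how a carboxylic acid or an amine on that ring would read out is also unresolved.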